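Compound 4 and the pentyl swap on the carbonyl carbon

A few compounds are considered here, and "the series" means these few. Any claim that something is new, unique, unknown or untested is made for them only; others in the source may bear on it.

Measured so far in a functional assay on NCI-H460 cells (Homo sapiens) for cytotoxicity, read by MTT assay, with a stated time of 48 h; a higher number here means a weaker inhibitor, a lower number a stronger inhibitor
- compound 1 `C=C1C(=O)O[C@H]2CC3=C[C@H](C/C(C)=C/[C@@H](OC(=O)c4ccc(C(C)=O)cc4)[C@H]12)OC3=O` gives 2200 nM
- compound 2 `C=C1C(=O)O[C@H]2CC3=C[C@H](C/C(C)=C/[C@@H](OC(=O)/C=C/c4ccc(N(C)C)cc4)[C@H]12)OC3=O` gives 1300 nM
- compound 3 `C=C1C(=O)O[C@H]2CC3=C[C@H](C/C(C)=C/[C@@H](OC(=O)/C=C/c4ccc(C(F)(F)F)cc4)[C@H]12)OC3=O` gives 1400 nM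

Compound 2 (1300 nM) cannot be told apart from the other two compounds, as its gaps to both lie within the scatter. The next compound to be read is compound 4 `C=C1C(=O)O[C@H]2CC3=C[C@H](C/C(C)=C/[C@@H](OC(=O)CCCCC)[C@H]12)OC3=O`. Its difference from compound 2 is pentyl in place of 2-(4-(dimethylamino)phenyl)ethenyl on a carbonyl carbon.

Among the compounds with values here, two measured steps bear on this change. The closer one acts at the same place and gives a 1.7-fold lower number from compound 1 to compound 2 (0.23 log units; within the scatter). The other, a swap of trifluoromethyl for dimethylamino on an aromatic carbon, gives a 1.1-fold higher number from compound 2 to compound 3 (0.03 log units; within the scatter). Both stay small, so the series has so far responded little to changes in this group. However, all three measured compounds carry an aromatic ring in it, and no measured compound shows what a chain without a ring does. The expectation therefore stays loose.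

In this assay the expected outcome is a 1.4-fold higher number from compound 2 to compound 4 (0.14 log units; within the scatter) and no shift beyond the scatter is expected. The estimated value for compound 4 is 1800 nM with an expected range from 700 nM to 4500 nM for the reading to come.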

Compound 4, half-maximal inhibitory concentration: 5900 nM
Estimate against measurement, compound 4: 3.3-fold (0.52 log units) below; measured number above the stated range.
By their numbers in this assay, from the lowest: compounds 2, 3 and 1 (each within the scatter of the next); then compound 4.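

In this assay, within the data shown here, the group on the carbonyl carbon turns out not to be indifferent: pentyl gives a 4.5-fold higher number from compound 2 to compound 4 (0.66 log units; beyond the scatter) and a 2.7-fold higher number from compound 1 to compound 4 (0.43 log units; beyond the scatter), whereas the earlier steps among ring-bearing groups stayed within the scatter. Among these compounds, the shift appears against two different leaving groups, 2-(4-(dimethylamino)phenyl)ethenyl and 4-acetylphenyl, so it is not tied to one particular aromatic partner, and compound 4 is the only compound of the four without a ring in this group. No measurement at hand speaks to why the step occurs.

Pentyl differs from the leaving groups both in lacking a ring and in its number of heavy atoms, so the compounds shown do not separate the loss of the aromatic ring from the shortening of the group. A cyclohexyl group, a longer chain such as octyl, or a pentyl chain carrying an amine on the same carbonyl carbon would bear on that question and show whether open chains as a class stand apart from the aromatic groups.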